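The source may report more compounds than this note shows. Statements on the series, on what has been measured and on what is new or still open speak of the compounds shown alone.

In a functional assay on L1210 cells (Mus musculus) for antiproliferative activity (a lower number here means a stronger inhibitor, a higher number a weaker inhibitor), compound 1 (`COc1ccc(-c2cc(N)c(C(=O)c3cc(OC)c(OC)c(OC)c3)s2)cc1OC`) gives 40 nM and compound 2 (`COc1cc(C(=O)c2sc(-c3ccc(Cl)cc3)cc2N)cc(OC)c1OC`) gives 93 nM as the higher of the two numbers. Compound 3 (`COc1cc(C(=O)c2sc(-c3cccc([N+](=O)[O-])c3)cc2N)cc(OC)c1OC`) remains unmeasured, and it carries 3-nitrophenyl in place of the 4-chlorophenyl of compound 2 (3-nitrophenyl in place of 4-chlorophenyl on an aromatic carbon) on the aromatic carbon next to the ring sulfur. Among the compounds with values here, the one measured step at this place is a 2.3-fold higher number from compound 1 to compound 2 (0.37 log units; beyond the scatter) and it is modest, so a modest step toward a higher number is expected in this assay, with the direction only loosely fixed by a single step. Compound 3 is estimated at 150 nM with an expected range from 40 nM to 600 nM overall. The estimate amounts to an expected 1.6-fold higher number from compound 2 to compound 3 (0.21 log units; within the scatter) in this series.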

Compound 3, half-maximal inhibitory concentration: 11 nM
Estimate against measurement, compound 3: 14-fold (1.13 log units) above; measured number outside the range, below it.
By their numbers in this assay, from the lowest: compound 3; then compound 1; then compound 2.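

In this assay the aromatic carbon next to the ring sulfur is more sensitive to the choice of aryl group than the first step showed, and the change can also lower the number. 3-nitrophenyl gives an 8.5-fold lower number from compound 2 to compound 3 (0.93 log units; beyond the scatter) and a 3.6-fold lower number from compound 1 to compound 3 (0.56 log units; beyond the scatter) as its two steps, so it stands lowest of the three aryl groups here. The compounds shown do not separate the nitro group from its placement on the ring, and 4-nitrophenyl or a 3-aminophenyl group would bear on that. Nothing at hand accounts for the low number of compound 3.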